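Chloro for Methoxy on the Urea Aryl Ring

The compounds below may be only part of what the source reports. "The series", "measured", "known", "first", "only" and "open" are said of these compounds alone.

The measured compounds:
compound 1 `Cc1cc(NC(=O)Nc2ccc([N+](=O)[O-])c(C(F)(F)F)c2)c2ccccc2n1` gives > 25000 nM, a limit of the assay.
compound 2 `COc1ccc(NC(=O)Nc2cc(C)nc3ccccc23)cc1` gives > 25000 nM, a limit of the assay.
compound 3 `Cc1cc(NC(=O)Nc2cccc(C(N)=O)c2)c2ccccc2n1` gives > 25000 nM, a limit of the assay.

All three share one core and differ only in the aryl group on the far side of the urea. They were tested in an ADME assay on BJ cells (Homo sapiens) for cytotoxicity, with a stated time of 72 h; a higher number here means that more compound is needed for the effect, a lower number that less compound is needed. Compound 2 stands where every measured compound stands: its result is a limit rather than a number, as described by the limit of > 25000 nM in this assay, at which 3 of the 3 values shown sit. Among the compounds with values here, no step between measured compounds can therefore be sized, and nothing separates compound 2 from compound 1 or compound 3 on these numbers.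

The unmeasured compound is compound 4 `Cc1cc(NC(=O)Nc2ccc(Cl)cc2)c2ccccc2n1`. It differs from compound 2 by chloro in place of methoxy on an aromatic carbon.

Within the data shown here, with no measured step to lean on and every measured value sitting as a limit, no step beyond the usual scatter is expected in this assay from this change. Since compound 2 gives > 25000 nM, compound 4 is expected to give about 30000 nM, within a range from 12000 nM to 70000 nM, most likely reported again as a limit. The expected step is a step that the limit leaves unreadable from compound 2 to compound 4.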

Compound 4, half-maximal effective concentration: > 25000 nM
Compound 4: a limit, no number; the forecaster's own chance of this, stated with the estimate: 80%; the middle value is on the limit's open side.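

In this assay compound 4 gives > 25000 nM, which is a limit of the assay and not a number. Compound 2 also sits at a limit, so no step can be read between compound 2 and compound 4. The compounds shown leave open whether any aryl group on the far side of the urea would give an actual number in this assay.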